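Notes on the step from compound 2 to compound 3

The compounds below may be only part of what the source reports. "The series", "measured", "known", "first", "only" and "open" are said of these compounds alone.

Compound 2 `CCCCOc1ccc(S(=O)(=O)N2CCC(N3CCC(C)CC3)CC2)cc1` gives 2300 nM in a functional assay on DLD-1 cells (Homo sapiens) for antiproliferative activity, read by CellTiter-Glo, with a stated time of 72 h (a higher number here means a weaker inhibitor, a lower number a stronger inhibitor), the higher of the two numbers measured; compound 1 `CC1CCN(C2CCN(S(=O)(=O)c3ccc(OCc4ccccc4)cc3)CC2)CC1` gives 385 nM. Going by the values given here, the only measured step, a 6.0-fold higher number from compound 1 to compound 2 (0.78 log units; beyond the scatter), is the nearest guide. Compound 3 `CC1CCN(C2CCN(S(=O)(=O)c3ccc(-c4ccc(Cl)cc4)cc3)CC2)CC1` carries the change (4-chlorophenyl in place of butoxy on an aromatic carbon). Among the compounds with values here, no measured step covers it directly; an aromatic ring enters where a chain leaves, which echoes the earlier step in reverse, though here the group sits on an aromatic carbon, not on a saturated chain carbon bound to an oxygen. A move toward compound 1 is expected, somewhat smaller than that step. Compound 3 is therefore estimated at 800 nM (range 250 nM to 2500 nM). The expected step is a 2.9-fold lower number from compound 2 to compound 3 (0.46 log units; beyond the scatter).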

Compound 3, half-maximal inhibitory concentration: 105 nM
Beside the measured number, compound 3's estimate is 7.6-fold (0.88 log units) above it, and the stated range ends above it.
By their numbers in this assay, from the lowest: compound 3; then compound 1; then compound 2.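

In this assay, a second aromatic ring attached directly at this aromatic carbon, without an oxygen link, outperforms both ethers: 4-chlorophenyl gives a 22-fold lower number from compound 2 to compound 3 (1.34 log units; beyond the scatter) against butoxy and a 3.7-fold lower number from compound 1 to compound 3 (0.56 log units; beyond the scatter) against benzyloxy. The oxygen link shared by compound 1 and compound 2 is therefore not required here, and compound 3 has the lowest number of the three. Nothing available explains this gain.

Whether the chlorine contributes remains open, since an unsubstituted phenyl is not among these compounds. So does whether a saturated ring such as cyclohexyl at this carbon would serve as well as the aromatic ring.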